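Phenyl for methyl on the acrylamide chain

This account rests on a few compounds, and the source may have more. Where it says the series, first, only, none or still open, it means among the compounds named here.

Measured compounds:
compound 1 `CC(C)C/C(=C\C(=O)Nc1ccc2c(c1)OCCO2)c1ccc(C(C)(C)C)cc1` gives 94 nM in a functional assay on CHO cells for inhibition of transient receptor potential cation channel subfamily V member 1 (Homo sapiens); on this read-out lower numbers stand for stronger inhibition and higher numbers for weaker inhibition;
compound 2 `C/C(=C\c1ccc(C(C)(C)C)cc1)C(=O)Nc1ccc2c(c1)OCCO2` gives 600 nM in this assay.

Among the two measured values, compound 2 holds the higher number, so it is the weaker inhibitor; compound 1 lies well beyond the scatter from it. Compound 3 `CC(C)(C)c1ccc(/C=C(/C(=O)Nc2ccc3c(c2)OCCO3)c2ccccc2)cc1` differs from compound 2 in one place: phenyl in place of methyl on a double-bonded chain carbon bound to a carbonyl carbon and a double-bonded chain carbon. Among the measured compounds shown here, no measured pair here isolates that change, so the direction is uncertain. The change from compound 2 to compound 3 is expected to give a modest gain, around a 2.0-fold lower number from compound 2 to compound 3 (0.30 log units; within the scatter), roughly at the edge of the scatter. Compound 3 is therefore estimated at 300 nM, within 80 nM to 1200 nM.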

Compound 3, half-maximal inhibitory concentration: > 4000 nM
Compound 3 gave a limit, no number (the forecaster's own chance of this, stated with the estimate: 5%); middle value at least 13-fold (1.12 log units) away from the limit.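

Replacing methyl with phenyl on this double-bonded chain carbon weakens inhibition, with an at least 6.6-fold higher number from compound 2 to compound 3 (0.82 log units; beyond the scatter). Among the compounds shown here, this is the first change in a single place that can be read here, and it shows that inhibition depends on what this carbon carries. The reading for compound 3 is a limit of the assay, not a number: the limit of > 4000 nM in this assay, at which 1 of the 3 values shown sits.

Still open, as far as these compounds go, is whether a smaller step up from methyl, such as an ethyl or a cyclopropyl group, would also weaken inhibition. Also open, from the compounds shown here alone, is how a plain hydrogen on this carbon would compare with methyl.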